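Compound 3 to compound 4: oxolan-3-yl for cyclopropylmethyl

The compounds below may be only part of what the source reports. "The series", "measured", "known", "first", "only" and "open" are said of these compounds alone.

In an ADME assay on H9c2 cells (Rattus norvegicus) for cytotoxicity (a higher number here means a weaker inhibitor, a lower number a stronger inhibitor), compound 1 (`CC(C)(C)C(=O)Nc1nc2ccc(Cl)cc2s1`) gives > 50000 nM as a limit of the assay and not a number. Compound 2 (`O=C(Nc1nc2ccc(Cl)cc2s1)C1CCC1`) gives > 50000 nM which is likewise a limit. Compound 3 (`O=C(CC1CC1)Nc1nc2ccc(Cl)cc2s1`) gives > 50000 nM as a limit too, so its standing carries no exact number.

Compound 4 (`O=C(Nc1nc2ccc(Cl)cc2s1)C1CCOC1`) has oxolan-3-yl in place of cyclopropylmethyl on a carbonyl carbon and thereby gains a hydrogen-bond acceptor.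

Going by the values given here, three measured steps bear on this change: a step that the two limits leave unreadable from compound 1 to compound 2 and a step that the two limits leave unreadable from compound 1 to compound 3 and a step that the two limits leave unreadable from compound 2 to compound 3 and none of them has a readable size. Among the compounds with values here, the series so far amounts to the limit of > 50000 nM in this assay, at which 3 of the 3 values shown sit, and offers no measured change on which to base a direction.

With compound 3 at > 50000 nM as a limit, no step beyond the scatter is expected in this assay and no direction is favoured. The expected step is a step that the limit leaves unreadable from compound 3 to compound 4 as an estimate only. Compound 4 is expected at 60000 nM with an estimated range from 25000 nM to 120000 nM and will most likely be reported as a limit.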

Compound 4, half-maximal inhibitory concentration: > 50000 nM
Compound 4 ended at the assay's limit (the forecaster's own chance of this, stated with the estimate: 85%); the middle value lies beyond the limit too.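

In this assay, going by these compounds alone, compound 4 gives > 50000 nM as a limit of the assay and not a number, so no step from compound 1, compound 2 or compound 3 to compound 4 can be read. The compounds shown leave open whether any group on this carbonyl carbon brings a measurable cytotoxic potency, with the series so far resting at one value: the limit of > 50000 nM in this assay, at which 4 of the 4 values shown sit.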